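Urea series: aryl swap on the urea nitrogen

This account rests on a few compounds, and the source may have more. Where it says the series, first, only, none or still open, it means among the compounds named here.

Measured so far:
compound 1, `CSc1ccc(NC(=O)N[C@H]2CC[C@H](Oc3ccc(F)cc3)CC2)cc1` — > 20000 nM
compound 2, `O=C(Nc1cccc(C(F)(F)F)c1)N[C@H]1CC[C@H](Oc2ccc(OC(F)(F)F)cc2)CC1` — 690 nM

Compound 1 stands at a limit of the assay: in a functional assay on CRL2813 cells (Homo sapiens) for cytotoxicity, read by sulforhodamine B assay, with a stated time of 5 days (a lower number here means a stronger inhibitor, a higher number a weaker inhibitor), compound 1 gives > 20000 nM, a limit and not a number, as the limit of > 20000 nM in this assay, at which 1 of the 2 values shown sits, records. Compound 2 differs from compound 1 in two places and is therefore not a single step; in this assay compound 2 gives 690 nM. Within the data shown here, no single-point step between measured compounds exists, so the size of the change is not anchored.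

Compound 3, `O=C(Nc1cccc([N+](=O)[O-])c1)N[C@H]1CC[C@H](Oc2ccc(F)cc2)CC1`, is the next candidate. It differs from compound 1 by 3-nitrophenyl in place of 4-(methylsulfanyl)phenyl on an amide-type nitrogen. Compound 1 is known only as a limit, so any gain is open-ended at the weak side. The expected step is an at least 2.5-fold lower number from compound 1 to compound 3 (0.39 log units; beyond the scatter), and this expectation is uncertain. Compound 3 is expected to give 8000 nM, within 1500 nM to 25000 nM.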

Compound 3, half-maximal inhibitory concentration: 6700 nM
Compound 3: middle estimate off by 1.2-fold (0.08 log units), on the high side; measured number inside the range.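

On the amide-type nitrogen, with the rest of the core of compound 1 unchanged, 3-nitrophenyl in place of 4-(methylsulfanyl)phenyl gives an at least 2.9-fold lower number from compound 1 to compound 3 (0.47 log units; beyond the scatter) in this assay. Among these compounds, this is the first single-place step, so the aryl group at this position alone is now seen to move the read-out, and compound 3 gives 6700 nM, a measured number. From the compounds shown here alone, the step starts from compound 1, which is a limit and not a number, and its true size stays open at the weak side: the limit of > 20000 nM in this assay, at which 1 of the 3 values shown sits.

The compounds shown leave open whether the change follows the nitro group or its place on the ring. Also open, going by these compounds, is whether an amine or a carboxylic acid in place of the nitro group would hold the value of compound 3.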